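Tolerance of a Trimethoxyphenyl Variant on Vero Cells

This account rests on a few compounds, and the source may have more. Where it says the series, first, only, none or still open, it means among the compounds named here.

Of the compounds shown here, three have been measured so far in an ADME assay on Vero cells (Chlorocebus sabaeus) for cytotoxicity, read by MTT assay, with a stated time of 72 h; a higher number here means that more compound is tolerated, a lower number that less compound is tolerated. Compound 1 `COc1ccc(/C=C/C(=O)c2ccccc2OCC(=O)NCCNc2ccnc3cc(Cl)ccc23)cc1` gives 25000 nM. Compound 2 `COc1ccc(/C=C/C(=O)c2ccc(OCC(O)CNCCNc3ccnc4cc(Cl)ccc34)cc2)cc1` gives 8030 nM, the lowest of the two numbers reported; the gap from compound 2 to compound 1 lies beyond the scatter, so compound 2 is tolerated less well than compound 1. Compound 3 `COc1cc(/C=C/C(=O)c2ccc(OC3CO3)cc2)cc(OC)c1OC`, which lacks the aminoquinoline chain of the other two, is reported in this assay as "not toxic" (no number reported), without a number.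

Compound 4 `COc1cc(/C=C/C(=O)c2ccc(OCC(O)CNCCNc3ccnc4cc(Cl)ccc34)cc2)cc(OC)c1OC` is compound 2 with one change: 3,4,5-trimethoxyphenyl in place of 4-methoxyphenyl on a double-bonded chain carbon bound to a double-bonded chain carbon. Among the compounds with values here, no pair of measured compounds differs by this change alone, so nothing measured tells how large a step to expect. Compound 3 carries the same trimethoxyphenyl group and is not toxic, but its core is different, so it is a weak guide. The expectation is a small rise in the tolerated concentration, of a size that may stay within the scatter, from compound 2 to compound 4 a 1.4-fold higher number from compound 2 to compound 4 (0.14 log units; within the scatter). Compound 4 is therefore estimated at 11000 nM in this assay, with a likely range from 4000 nM to 30000 nM.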

Compound 4, half-maximal cytotoxic concentration: 1910 nM
Compound 4: the middle estimate sits 5.8-fold (0.76 log units) above what was measured; measured number outside the range, below it.
By their numbers in this assay, from the lowest: compound 4; then compound 2; then compound 1.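

In this assay, the change to 3,4,5-trimethoxyphenyl in place of 4-methoxyphenyl, on a double-bonded chain carbon bound to a double-bonded chain carbon, now has a measured size: a 4.2-fold lower number from compound 2 to compound 4 (0.62 log units; beyond the scatter). This shows that the position is not silent in this assay, since replacing one aryl group with a more heavily substituted one is enough to move the tolerated concentration beyond the usual scatter, and here the movement is towards less compound being tolerated. Nothing available explains why the number falls, so the step stands as an observation from a single pair of compounds, and no general rule can be drawn from it.

The compounds shown leave open how the number would respond to other groups at this place, such as a plain phenyl, a hydroxyphenyl or a chlorophenyl ring, and so whether it tracks the number of methoxy groups or something particular to the trimethoxyphenyl group. They also leave open whether the same change would produce a step of similar size and direction on the core of compound 1, with its amide-containing chain.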